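The source may report more compounds than this note shows. Statements on the series, on what has been measured and on what is new or still open speak of the compounds shown alone.

Measured in a functional assay on HepG2 cells (Homo sapiens) for antiproliferative activity, read by MTT assay, with a stated time of 48 h; a lower number here means a stronger inhibitor, a higher number a weaker inhibitor:
- Compound 1 `COc1ccc(N(C)c2ccnc(Cl)n2)cc1Cl`: 2630 nM
- Compound 2 `COc1ccc(N(C)c2ccnc(Cl)n2)cc1OCCCCCBr`: > 10000 nM (a limit of the assay, not a number)

Compound 2 has no exact place on the numbers, since its result is a limit: the limit of > 10000 nM in this assay, at which 1 of the 2 values shown sits.

Compound 3 `COc1ccc(N(C)c2ccnc(Cl)n2)cc1OCC[Se]C#N` is not yet measured. It keeps the core of compound 2 but changes the end of the chain, on a saturated chain carbon, two bonds along the chain from an oxygen on an aromatic ring: a group of 3 heavy atoms (1 carbon, 1 nitrogen, 1 selenium; no ring) in place of a group of 4 heavy atoms (3 carbon, 1 bromine; no ring), on a saturated chain carbon, two bonds along the chain from an oxygen on an aromatic ring.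

Going by the values given here, only one measured step bears on this change, and only indirectly: an at least 3.8-fold higher number from compound 1 to compound 2 (0.58 log units; beyond the scatter). That step lies beyond the scatter and brought in the (5-bromopentyl)oxy group in place of chloro. Among the compounds with values here, no measured compound carries the entering group, so the data give no direct size for this swap. Compound 1, at 2630 nM, shows that this core can give a real number in this assay, so a move towards a lower number is expected, though with wide uncertainty.

The expected step, estimated from a limit, is an at least 2.5-fold lower number from compound 2 to compound 3 (0.39 log units; beyond the scatter).

For compound 3 the estimated value is 4000 nM, with an expected range from 800 nM to 15000 nM.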

Compound 3, half-maximal inhibitory concentration: 1670 nM
Compound 3: middle estimate off by 2.4-fold (0.38 log units), on the high side; measured number inside the range.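

In this assay, replacing the 3-bromopropyl end of the chain with the selenium-bearing group gives an at least 5.9-fold lower number from compound 2 to compound 3 (0.77 log units; beyond the scatter). Going by these compounds alone, this is the first sign that the chain at this position can carry a measurable effect in these cells, and that what sits at its end matters, since the bromine-ended chain gave no exact value. Compound 2's result is a limit of the assay and not a number, so the true size of this step stays unknown: the limit of > 10000 nM in this assay, at which 1 of the 3 values shown sits.

The comparison with the chlorine compound gives a 1.6-fold lower number from compound 1 to compound 3 (0.20 log units; within the scatter), so the two cannot be told apart in this assay, and the long selenium-bearing side chain has not been shown to beat a single chlorine atom. Still open, as far as these compounds go, is which part of the new group counts: a sulfur atom in place of the selenium, or a plain nitrile on the chain, would separate the selenium from the nitrile, while a longer chain with the same end would show whether chain length plays a part.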